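The compounds below may be only part of what the source reports. "The series", "measured", "known", "first", "only" and "open" are said of these compounds alone.

Compound 1 `O=C(NO)c1ccc(CN(C2CC2)S(=O)(=O)c2cc(F)c(F)c(F)c2F)cc1`: 8.5 nM
Compound 2 `CC(C)CN(Cc1ccc(C(=O)NO)cc1)S(=O)(=O)c1cc(F)c(F)c(F)c1F`: 24.6 nM
Compound 3 `CC(C)N(Cc1ccc(C(=O)NO)cn1)S(=O)(=O)c1cc(F)c(F)c(F)c1F`: 121 nM

In an assay on Sf9 cells for inhibition of protein deacetylase HDAC6 (Homo sapiens), read by fluorescence and mobility shift assay (a lower number here means a stronger inhibitor, a higher number a weaker inhibitor), compound 2 holds the second highest of the three numbers; compound 1 gives a lower value and compound 3 a higher one. Compound 4 `O=C(NO)c1ccc(CN(C2CCCC2)S(=O)(=O)c2cc(F)c(F)c(F)c2F)cc1` differs from compound 2 by cyclopentyl in place of isobutyl on a sulfonamide nitrogen. Among the measured compounds shown here, the only measured step that touches the same position is a 2.9-fold higher number from compound 1 to compound 2 (0.46 log units; beyond the scatter), a modest change when the cyclopropyl of compound 1 is exchanged for the isobutyl of compound 2. Compound 3 changes a different part of the molecule and does not bear on this step. Returning to a ring on the sulfonamide nitrogen is expected to move the number back toward that of compound 1, though a cyclopentyl ring is not a cyclopropyl ring, so a smaller move is expected than the full reversal. Compound 4 is therefore expected to give 15 nM, with a likely range of 6 nM to 40 nM. The expected step is a 1.6-fold lower number from compound 2 to compound 4 (0.21 log units; within the scatter), an estimated modest improvement that may still sit close to the scatter.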

Compound 4, half-maximal inhibitory concentration: 49.9 nM
For compound 4 the middle estimate is 3.3-fold (0.52 log units) below the measured one, outside the stated range (above it).
By their numbers in this assay, from the lowest: compound 1; then compound 2; then compound 4; then compound 3.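

In this assay, a ring on the sulfonamide nitrogen does not by itself give the lower number: the cyclopentyl group brings a 2.0-fold higher number from compound 2 to compound 4 (0.31 log units; beyond the scatter), and the larger ring also gives a 5.9-fold higher number from compound 1 to compound 4 (0.77 log units; beyond the scatter). The open-chain isobutyl of compound 2 therefore ranks ahead of one ring and behind the other, so ring presence alone does not set the order among these compounds. No evidence at hand accounts for this order. Still open, from the compounds shown here alone, is whether cyclobutyl or cyclohexyl on that nitrogen would extend the trend from cyclopropyl to cyclopentyl, and where a shorter chain such as ethyl would rank.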